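Trifluoromethyl in place of methoxy on the pendant phenyl ring

The source may report more compounds than this note shows. Statements on the series, on what has been measured and on what is new or still open speak of the compounds shown alone.

Measured compounds:
compound 1 `COc1cc(-c2ccnc3cc(-c4ccc(C(C)=O)cc4)nn23)cc(OC)c1OC`, 1810 nM
compound 2 `COc1cc(-c2ccnc3cc(-c4ccc(N(C)C)cc4)nn23)cc(OC)c1OC`, 378 nM
compound 3 `COc1ccc(-c2cc3nccc(-c4cc(OC)c(OC)c(OC)c4)n3n2)cc1`, 373 nM

The three compounds share one core and differ only in the group on the pendant phenyl ring. In a functional assay on HeLa cells (Homo sapiens) for inhibition, read by CCK-8 assay, with a stated time of 48 h (a higher number here means a weaker inhibitor, a lower number a stronger inhibitor), compound 1 gives 1810 nM, and compound 2 gives 378 nM. Compound 3 gives the lowest of the three numbers, 373 nM, but the step of a 1.0-fold lower number from compound 2 to compound 3 (0.01 log units; within the scatter) lies within the scatter, so the two cannot be ordered. Both of the larger steps lead away from the acetyl: a 4.8-fold lower number from compound 1 to compound 2 (0.68 log units; beyond the scatter) and a 4.9-fold lower number from compound 1 to compound 3 (0.69 log units; beyond the scatter).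

Compound 4 `COc1cc(-c2ccnc3cc(-c4ccc(C(F)(F)F)cc4)nn23)cc(OC)c1OC` carries trifluoromethyl in place of methoxy on an aromatic carbon. For the measured compounds named here, no measured step involves a trifluoromethyl, so the only guide is that the one group unlike methoxy or dimethylamino, the acetyl of compound 1, gave a clearly higher number in this assay. On that basis compound 4 is expected to be weaker than compound 3, by a step estimated at a 2.7-fold higher number from compound 3 to compound 4 (0.43 log units; beyond the scatter). The estimate for compound 4 is therefore 1000 nM, within a range from 350 nM to 3000 nM.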

Compound 4, half-maximal inhibitory concentration: 1840 nM
Estimate against measurement, compound 4: 1.8-fold (0.26 log units) below; measured number inside the range.
By their numbers in this assay, from the lowest: compounds 3 and 2 (each within the scatter of the next); then compounds 1 and 4 (each within the scatter of the next).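

In this assay, trifluoromethyl at this place, para to a large group, gives a clear loss against the two groups that stood at the low end: a 4.9-fold higher number from compound 3 to compound 4 (0.69 log units; beyond the scatter) and a 4.9-fold higher number from compound 2 to compound 4 (0.69 log units; beyond the scatter). By contrast, a 1.0-fold higher number from compound 1 to compound 4 (0.01 log units; within the scatter) leaves trifluoromethyl and acetyl unresolved, so the high end of the series, previously represented by acetyl alone, now holds two groups, with methoxy and dimethylamino forming a separate pair at the low end. No measurement in hand explains this split.

The compounds shown leave open whether other groups at this place, such as a carboxylic acid, a primary amine or a longer alkoxy chain, fall into one of these two pairs or outside them. They also leave open whether the same steps would appear if the methoxy groups on the shared core were replaced by hydroxyl groups.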